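Bromo for Trifluoromethyl: Expected Clearance of Compound 3

A few compounds are considered here, and "the series" means these few. Any claim that something is new, unique, unknown or untested is made for them only; others in the source may bear on it.

Compound 1, `Brc1cccc2c1nnn2CC1CC1`, gives 7.7 mL/min/g in an ADME assay on microsomes from liver (Mus musculus, strain NMRI) for metabolic stability, tested at 2.5 uM; on this read-out lower numbers stand for slow clearance and higher numbers for fast clearance.
Compound 2, `FC(F)(F)c1cc(Br)c2nnn(CC3CC3)c2c1`, gives 7.7 mL/min/g in this assay.

Compound 2 stands level with compound 1 at the digits shown; the single measured step, no change at the digits printed from compound 1 to compound 2 (within the scatter), lies within the scatter. Compound 3, `Brc1cc(Br)c2nnn(CC3CC3)c2c1`, differs from compound 2 in one place: bromo in place of trifluoromethyl on an aromatic carbon. Going by the values given here, no measured pair shows this exchange directly. Among the compounds with values here, the only step available, no change at the digits printed from compound 1 to compound 2 (within the scatter), concerns the same position and is flat, so the one comparison on record suggests that a change at this position need not move the read-out. On that basis compound 3 is expected to stay close to compound 2, with a step of no change at the digits printed from compound 2 to compound 3 (within the scatter) expected in this assay, that is, none beyond the scatter. Compound 3 is therefore estimated at 7.7 mL/min/g, with a range from 4 mL/min/g to 15 mL/min/g.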

Compound 3, intrinsic clearance in a liver preparation (reported as CLH), per the amount of preparation that the assay uses: 15.3 mL/min/g
Estimate against measurement, compound 3: 2.0-fold (0.30 log units) below; the whole stated range lies below it.
By their numbers in this assay, from the lowest: compounds 1, 2 and 3 (each within the scatter of the next).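

With bromo in place of trifluoromethyl, the number moves by a 2.0-fold higher number from compound 2 to compound 3 (0.30 log units; within the scatter), and with bromo in place of hydrogen it moves by a 2.0-fold higher number from compound 1 to compound 3 (0.30 log units; within the scatter). Compound 1 and compound 2 had shown only one exchange at this position, with a flat result; there are now three groups at this position, hydrogen, trifluoromethyl and bromo, and all three values stay within the scatter of one another in this assay. Unlike that first flat pair, the two new steps show a difference at the digits printed, but neither goes beyond the scatter, so no group at this position stands apart.

The compounds shown leave open whether an amine or a carboxylic acid at this position would also stay within the scatter, and whether exchanging the bromo that all three compounds share would do the same. Nothing available bears on why these numbers fall as they do.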